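Swapping a Methoxy for an Oxolanyloxy Ether

The source may report more compounds than this note shows. Statements on the series, on what has been measured and on what is new or still open speak of the compounds shown alone.

Compound 1 `COc1ccc(/C=C/C(=O)Nc2cc3c(Nc4ccc(F)c(Cl)c4)ncnc3cc2OC)c(OC)c1` is one of three measured compounds built on a shared core. In a functional assay on MCF7 cells (Homo sapiens) for cytotoxicity, read by MTT assay, with a stated time of 72 h (on this read-out higher numbers stand for weaker inhibition and lower numbers for stronger inhibition), compound 1 gives 36600 nM. Compound 2 `COc1cc(/C=C/C(=O)Nc2cc3c(Nc4ccc(F)c(Cl)c4)ncnc3cc2O[C@H]2CCOC2)cc(OC)c1O` gives 30500 nM, and compound 3 `O=C(/C=C/c1cccc(Cl)c1Cl)Nc1cc2c(Nc3ccc(F)c(Cl)c3)ncnc2cc1O[C@H]1CCOC1` gives 30100 nM. All three numbers lie within the usual scatter of one another, so compound 1 cannot be set apart from the other two on these data. The unmeasured compound 4 `COc1ccc(/C=C/C(=O)Nc2cc3c(Nc4ccc(F)c(Cl)c4)ncnc3cc2O[C@H]2CCOC2)c(OC)c1` arises from compound 1 by a single change: oxolan-3-yl in place of methyl on an oxygen on an aromatic ring. Going by the values given here, no measured pair shows this change directly. Among the compounds with values here, the only measured step, a 1.0-fold lower number from compound 2 to compound 3 (0.01 log units; within the scatter), alters a different part of the molecule and stays within the scatter, and compounds 2 and 3, which already carry the oxolan-3-yl group on that oxygen, give numbers sitting within the scatter of compound 1. Compound 4 is therefore expected to show no step beyond the scatter, with a 1.1-fold lower number from compound 1 to compound 4 (0.04 log units; within the scatter). The estimate for compound 4 is 33000 nM, with a range from 15000 nM to 70000 nM.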

Compound 4, half-maximal inhibitory concentration: 28600 nM
Beside the measured number, compound 4's estimate is 1.2-fold (0.06 log units) above it; the measured number falls inside the stated range.
By their numbers in this assay, from the lowest: compounds 4, 3, 2 and 1 (each within the scatter of the next).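

In this assay, the direct pair now exists: oxolan-3-yl in place of methyl on this oxygen brings a five-membered ring and five heavy atoms in place of one, yet the step stays within the scatter (a 1.3-fold lower number from compound 1 to compound 4 (0.11 log units; within the scatter)), so this position accepts the change with no detectable shift in the number. With oxolan-3-yl held in place, 2,4-dimethoxyphenyl also stays within the scatter, both against 2,3-dichlorophenyl (a 1.1-fold lower number from compound 3 to compound 4 (0.02 log units; within the scatter)) and against 4-hydroxy-3,5-dimethoxyphenyl (a 1.1-fold lower number from compound 2 to compound 4 (0.03 log units; within the scatter)), so none of these three aromatic groups is set apart on this ether. Nothing available here speaks to why these numbers stay together.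

The compounds shown leave open whether an amine or a longer chain on this oxygen would move the number beyond the scatter. The mirror-image form of the oxolan-3-yl group also remains an open question.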